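The compounds below may be only part of what the source reports. "The series", "measured", "known", "first", "only" and "open" are said of these compounds alone.

Compound 1 `Fc1ccc(N2CCN(c3nc(-n4ccc5ccccc54)c4ccccc4n3)CC2)cc1` gives 50 ug/mL in an ADME assay on Vero cells (Chlorocebus sabaeus) for antiproliferative activity, read by MTT assay; on this read-out higher numbers stand for weaker inhibition and lower numbers for stronger inhibition. Within the data shown here, it has no standout position among the compounds measured so far. Compound 2 `COc1ccc(-c2nc(N3CCNCC3)nc3ccccc23)c(OC)c1` gives 50 ug/mL, and compound 3 `CN1CCN(c2nc(-c3cn(C)c4ccccc34)c3ccccc3n2)CC1` gives 50 ug/mL, so all three sit at the same value even though their structures differ in more than one place. Among the measured compounds shown here, that shared value is worth noting, but it does not show which structural features matter, and no pair of measured compounds isolates a single change.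

The next compound to be tested is compound 4 `c1ccc(N2CCN(c3nc(-n4ccc5ccccc54)c4ccccc4n3)CC2)nc1`. It keeps the core of compound 1 and alters one group, with pyridin-2-yl in place of 4-fluorophenyl on an amine nitrogen in a ring. The data hold no direct measurement of this swap, so any forecast has to lean on the flat picture so far. Compound 2 at 50 ug/mL and compound 3 at 50 ug/mL match compound 1 at 50 ug/mL despite their differences, so no shift beyond the usual scatter is expected in this assay. The estimated step of no change at the digits printed from compound 1 to compound 4 (within the scatter) therefore has no clear direction. Compound 4 is expected to give about 50 ug/mL, with an estimated range from 25 ug/mL to 100 ug/mL.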

Compound 4, half-maximal inhibitory concentration: 50 ug/mL
Compound 4: the middle estimate sits on the measured number at the digits printed; the measured number falls inside the stated range.
By their numbers in this assay, from the lowest: compounds 1, 2, 3 and 4 (each within the scatter of the next).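

In this assay, among these compounds, pyridin-2-yl in place of 4-fluorophenyl on the amine nitrogen in the ring gives no change at the digits printed from compound 1 to compound 4 (within the scatter), and this is the first comparison in the set that isolates a single change. It shows that, at this position, a carbon-only aromatic ring bearing fluorine and an aromatic ring with one hetero atom give the same result in this assay, even though the entering group has one fewer heavy atom and adds a hydrogen-bond acceptor. No supporting measurement explains this flat result, so the comparison records what happened without showing the reason for it.

From the compounds shown here alone, what remains open is whether a group of a different kind at this position, such as a carboxylic acid, a primary amine or a longer alkyl chain, would move the number beyond the usual scatter. This single swap between two six-membered aromatic rings also says nothing about how changes elsewhere on the core of compound 1 would read out in this assay, so the flat picture cannot yet be extended beyond this one position.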